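The source may hold more compounds than are shown below. What is called first, only, known or untested is meant among the compounds shown, and "the series" means these compounds.

Compound 2 `Oc1cccc(C(Nc2ccccn2)c2ccc3cccnc3c2O)c1Cl` is the strongest of the three measured compounds here: in an assay for inhibition of protein disulfide-isomerase (Homo sapiens), with a stated time of 1 h (a higher number here means a weaker inhibitor, a lower number a stronger inhibitor), compound 2 gives 370 nM. Compound 1 `Oc1cc(F)ccc1C(c1ccc2ccoc2c1O)N1CCCCC1` gives 1070 nM in this assay, a gap beyond the scatter, and compound 3 `Cc1ccnc(NC(c2ccc(C(F)(F)F)cc2)c2ccc3cccnc3c2O)c1` gives 26500 nM, far beyond the scatter. Compound 4 `Cc1cc(C)c(C(Nc2ccccn2)c2ccc3cccnc3c2O)c(C)c1` has not yet been measured. It differs from compound 2 in one place: 2,4,6-trimethylphenyl in place of 2-chloro-3-hydroxyphenyl on a saturated chain carbon bound to an aromatic carbon and a nitrogen on an aromatic ring. Within the data shown here, no measured pair shows exactly this exchange, so the expectation rests on what the three values show. The entering 2,4,6-trimethylphenyl carries no hydrogen-bond donor or acceptor, while the leaving group carried one of each, and the weakest measured compound, compound 3, which also lacks a hydroxyl on its aryl group, gives 26500 nM. Compound 4 is therefore expected to be a weaker inhibitor than compound 2, by a step of a 14-fold higher number from compound 2 to compound 4 (1.13 log units; beyond the scatter) beyond the scatter. The estimated value for compound 4 in this assay is 5000 nM, with a range from 1000 nM to 30000 nM.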

Compound 4, half-maximal inhibitory concentration: 190 nM
Estimate against measurement, compound 4: 26-fold (1.42 log units) above; measured number outside the range, below it.
By their numbers in this assay, from the lowest: compounds 4 and 2 (each within the scatter of the next); then compound 1; then compound 3.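

At this position, on a saturated chain carbon bound to an aromatic carbon and a nitrogen on an aromatic ring, replacing 2-chloro-3-hydroxyphenyl with 2,4,6-trimethylphenyl gives a 1.9-fold lower number from compound 2 to compound 4 (0.29 log units; within the scatter) in this assay, so the two compounds cannot be told apart. The entering group carries no hydrogen-bond donor or acceptor, which shows that, on this shared core, inhibition in this range does not depend on the hydroxyl or the chlorine of the leaving group. Nothing available accounts for this tolerance.

The compounds shown leave open whether an unsubstituted phenyl or a cyclohexyl at this position would keep the value of compound 4 at 190 nM. They also leave open how a carboxylic acid or a primary amine on the aromatic ring would fare.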